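Swapping pyridin-3-yl for benzyl: expected clearance of compound 3

This account rests on a few compounds, and the source may have more. Where it says the series, first, only, none or still open, it means among the compounds named here.

Measured so far in an ADME assay on liver (Homo sapiens) for metabolic stability, read by LC-MS, using microsomes and NADPH, with a stated time of 15 min, tested at 1 uM (a lower number here means slower removal, a higher number faster removal of the compound), are two compounds
Compound 1 `C[C@@H]1CN(Cc2ccccc2)c2nc(C(F)(F)F)ccc2[C@H](C)N1C(=O)NCc1ccccc1` gives 531 mL.min-1.g-1
Compound 2 `C[C@@H]1CN(Cc2ccccc2)c2cncc(F)c2[C@H](C)N1C(=O)Nc1cccnc1` gives 83 mL.min-1.g-1

Of these two, compound 2 has the lower number (83 mL.min-1.g-1), so it is removed more slowly, and the gap up to compound 1 lies beyond the usual scatter. Compound 3 `C[C@@H]1CN(Cc2ccccc2)c2cncc(F)c2[C@H](C)N1C(=O)NCc1ccccc1` keeps the core of compound 2 and alters one group, counted here as benzyl in place of pyridin-3-yl on an amide-type nitrogen. Among the measured compounds shown here, no two measured compounds differ in one place only, so no measured step speaks directly to this change. Compound 1 also carries benzyl on an amide-type nitrogen and gives 531 mL.min-1.g-1 in this assay but its core differs as well, so this value offers only a hint of direction. A moderate rise in the number is expected, smaller than the whole gap between the two measured compounds, and the estimated change is a 2.4-fold higher number from compound 2 to compound 3 (0.38 log units; beyond the scatter) on this thin evidence. For compound 3 the estimated value is 200 mL.min-1.g-1 with an expected range from 80 mL.min-1.g-1 to 500 mL.min-1.g-1 as its likely span.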

Compound 3, intrinsic clearance in microsomes: 185 mL.min-1.g-1
Estimate against measurement, compound 3: 1.1-fold (0.03 log units) above; the measured number falls inside the stated range.
By their numbers in this assay, from the lowest: compound 2; then compound 3; then compound 1.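

Among the compounds shown here, compound 2 and compound 3 are the first pair here that differ in one place only, so the change on the amide-type nitrogen can now be read on its own, with the shared core held fixed. In this assay, benzyl in place of pyridin-3-yl gives a 2.2-fold higher number from compound 2 to compound 3 (0.35 log units; beyond the scatter), a modest step but one that lies beyond the usual scatter, which shows that the group on this nitrogen does affect how fast the compound is removed. Pyridin-3-yl and benzyl differ in more than one way, and nothing measured here says which part of the swap, the ring of carbon only or the larger benzyl group, goes with the rise.

The compounds shown leave open whether a phenyl or a pyridin-3-ylmethyl group on the same nitrogen would stay nearer compound 2 or compound 3, which would help to separate those two parts of the swap. As far as these compounds go, it also remains open whether the same swap gives a step of similar size and direction on the core of compound 1, which carries a trifluoromethyl group.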